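This account rests on a few compounds, and the source may have more. Where it says the series, first, only, none or still open, it means among the compounds named here.

Measured so far in a functional assay on HCT-116 cells (Homo sapiens) for cytotoxicity; a lower number here means a stronger inhibitor, a higher number a weaker inhibitor:
- compound 1 `COc1cc(N2CCN(C(=O)C3CCC(O)CC3)CC2)ccc1Nc1nc(NC2CCCCC2)c2nc[nH]c2n1`: 15 nM
- compound 2 `COc1cc(N2CCN(C(=O)N3CCN(C)CC3)CC2)ccc1Nc1nc(NC2CCCCC2)c2nc[nH]c2n1`: 17 nM
- compound 3 `COc1cc(N2CCN(Cc3ccccn3)CC2)ccc1Nc1nc(NC2CCCCC2)c2nc[nH]c2n1`: 51 nM

Compound 1 stands at the low-number end of this small set, level with compound 2 (a 1.1-fold higher number from compound 1 to compound 2 (0.05 log units; within the scatter)). Compound 3 reads higher than both.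

Next is compound 4 `COc1cc(N2CCN(CC3CCOC3)CC2)ccc1Nc1nc(NC2CCCCC2)c2nc[nH]c2n1`, where (oxolan-3-yl)methyl takes the place of (4-hydroxycyclohexyl)carbonyl on an amine nitrogen in a ring: (oxolan-3-yl)methyl in place of (4-hydroxycyclohexyl)carbonyl on an amine nitrogen in a ring

For the measured compounds named here, the nearest precedent is compound 3, which also has a ring joined through a methyl group instead of a carbonyl at this nitrogen (a 3.4-fold higher number from compound 1 to compound 3 (0.53 log units; beyond the scatter)). The matching step from the other carbonyl compound is of similar size (a 3.0-fold higher number from compound 2 to compound 3 (0.48 log units; beyond the scatter)). Both are modest, while exchanging one carbonyl substituent for another stayed within the scatter (a 1.1-fold higher number from compound 1 to compound 2 (0.05 log units; within the scatter)). Going by the values given here, this comparison rests on compound 3 alone, and no measured compound carries an oxolane ring, so a result within the scatter of compound 1 remains possible. Among the compounds with values here, a modest step towards a higher number is therefore expected in this assay, similar in size to the one seen for compound 3.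

The estimated change is a 2.7-fold higher number from compound 1 to compound 4 (0.43 log units; beyond the scatter).

Compound 4 is expected at about 40 nM, with an estimated range of 15 nM to 110 nM.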

Compound 4, half-maximal inhibitory concentration: 66 nM
Estimate against measurement, compound 4: 1.7-fold (0.22 log units) below; the measured number falls inside the stated range.
By their numbers in this assay, from the lowest: compounds 1 and 2 (each within the scatter of the next); then compounds 3 and 4 (each within the scatter of the next).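

With (oxolan-3-yl)methyl at this amine nitrogen, this assay gives a second case of a ring joined through a methyl group in place of a carbonyl substituent, and both steps from the carbonyl compounds are modest and beyond the scatter (a 4.4-fold higher number from compound 1 to compound 4 (0.64 log units; beyond the scatter); a 3.9-fold higher number from compound 2 to compound 4 (0.59 log units; beyond the scatter)). Exchanging pyridin-2-yl for oxolan-3-yl on the saturated chain carbon stays within the scatter (a 1.3-fold higher number from compound 3 to compound 4 (0.11 log units; within the scatter)), so among these four compounds the split follows the link to the nitrogen rather than the ring on the methyl-linked side, and no compound goes against it. Nothing available explains this split.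

The compounds shown do not separate the carbonyl link from the larger groups it carries, and a plain acetyl group on this nitrogen would test the carbonyl with no ring attached. From the compounds shown here alone, it also remains open whether the two methyl-linked results extend to an amine-bearing ring such as (piperidin-4-yl)methyl, or to a longer chain between the nitrogen and the ring.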